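Moving the nitro group: compound 2 to compound 4

The source may report more compounds than this note shows. Statements on the series, on what has been measured and on what is new or still open speak of the compounds shown alone.

In a physicochemical assay for lipophilicity (on this read-out lower numbers stand for lower lipophilicity and higher numbers for higher lipophilicity), compound 1 (`O=C1/C(=C/c2ccccc2)CCC/C1=C\c1ccccc1[N+](=O)[O-]`) gives 4.7 as its reading and compound 2 (`CN(C)c1ccc(/C=C2\CCC/C(=C\c3ccccc3[N+](=O)[O-])C2=O)cc1`) gives 4.8 as its reading, while compound 3 (`COc1ccc(/C=C2\CCC/C(=C\c3ccccc3[N+](=O)[O-])C2=O)cc1`) gives 4.76 on the same scale. Compound 2 stands level with the other two, and the three numbers cannot be ranked: the data show a number 0.10 log units higher from compound 1 to compound 2 (within the scatter) as one step, a number 0.06 log units higher from compound 1 to compound 3 (within the scatter) as a second and a number 0.04 log units lower from compound 2 to compound 3 (within the scatter) as a third.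

The next change leads to compound 4 (`CN(C)c1ccc(/C=C2\CCC/C(=C\c3ccc([N+](=O)[O-])cc3)C2=O)cc1`), with 4-nitrophenyl in place of 2-nitrophenyl on a double-bonded chain carbon bound to a double-bonded ring carbon. For the measured compounds named here, no measured step moves the nitro group, and no pair of compounds differs in this way. The three steps concern only dimethylamino, methoxy and hydrogen on an aromatic carbon, so they bear on this change only indirectly. The expectation therefore rests on compound 2 at 4.8 as the anchor and on the small size of the step shown as a number 0.04 log units lower from compound 2 to compound 3 (within the scatter) in this series. The estimate is a number 0.05 log units higher from compound 2 to compound 4 (within the scatter) and no step beyond the scatter is expected in this assay for this change. For compound 4 the estimated value is 4.85 with an expected range from 4.5 to 5.2 on this scale.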

Compound 4, partition coefficient: 5.03
Beside the measured number, compound 4's estimate is 0.18 log units below it; the range from low to high includes it.
By their numbers in this assay, from the lowest: compounds 1, 3, 2 and 4 (each within the scatter of the next, the first and the last beyond it).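

In this assay, for the compounds shown here, the exchange of 2-nitrophenyl for 4-nitrophenyl on a double-bonded chain carbon bound to a double-bonded ring carbon gives a number 0.23 log units higher from compound 2 to compound 4 (within the scatter) and is the first reading at this place, as the earlier steps concerned only hydrogen, dimethylamino and methoxy on an aromatic carbon. In size it is the largest step in the series so far, yet like those three steps it stays within the scatter, so compound 2 and compound 4 cannot be told apart and this place has not yet been shown to alter the reading. Nothing at hand bears on the origin of this step.

As far as these compounds go, the series holds this exchange of nitrophenyl groups only once, so whether it gives a step of similar size with methoxy or hydrogen in place of dimethylamino stays open. From the compounds shown here alone, how a carboxylic acid or a nitrile in place of the nitro group would read at this place in this assay also stays open.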